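Swapping the aryl group: from fluorophenyl to dimethoxyphenyl

This account rests on a few compounds, and the source may have more. Where it says the series, first, only, none or still open, it means among the compounds named here.

Of the compounds shown here, three share one core and have been tested in a functional assay on A549 cells (Homo sapiens) for cytotoxicity, read by MTT assay, with a stated time of 48 h; on this read-out lower numbers stand for stronger inhibition and higher numbers for weaker inhibition. Compound 1 `COc1ccc(-c2cc(C(=O)Nc3nc4ccc(Cl)cc4s3)nc3cc(-c4ccccc4)nn23)cc1OC` gives 6160 nM. Compound 2 `COc1ccc(-c2cc(C(=O)Nc3nc4ccc(F)cc4s3)nc3cc(-c4ccccc4)nn23)cc1OC` gives 6910 nM; the step of a 1.1-fold higher number from compound 1 to compound 2 (0.05 log units; within the scatter) shows that this exchange barely matters. Compound 3 `COc1ccc2nc(NC(=O)c3cc(-c4ccc(F)cc4)n4nc(-c5ccccc5)cc4n3)sc2c1` gives 24000 nM, the highest number of the three, beyond the scatter from both compound 1 and compound 2.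

Compound 4 `COc1ccc2nc(NC(=O)c3cc(-c4ccc(OC)c(OC)c4)n4nc(-c5ccccc5)cc4n3)sc2c1` is compound 3 with one change: 3,4-dimethoxyphenyl in place of 4-fluorophenyl on an aromatic carbon. Going by the values given here, no measured pair covers exactly this exchange, so the only guide is indirect. Compound 1 and compound 2 both carry the 3,4-dimethoxyphenyl group that enters here, and both give clearly lower numbers than compound 3, although they also differ from compound 3 elsewhere. On that basis the number for compound 4 is expected to fall, with the step of a 3.0-fold lower number from compound 3 to compound 4 (0.48 log units; beyond the scatter) judged to be beyond the scatter. The estimate for compound 4 in this assay is 8000 nM, expected to lie between 3000 nM and 25000 nM.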

Compound 4, half-maximal inhibitory concentration: 15800 nM
Compound 4: the middle estimate sits 2.0-fold (0.30 log units) below what was measured; the measured number falls inside the stated range.
By their numbers in this assay, from the lowest: compounds 1 and 2 (each within the scatter of the next); then compounds 4 and 3 (each within the scatter of the next).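

In this assay, putting 3,4-dimethoxyphenyl in place of 4-fluorophenyl at this position gives a 1.5-fold lower number from compound 3 to compound 4 (0.18 log units; within the scatter), so on its own this exchange makes no clear difference. With 3,4-dimethoxyphenyl held fixed, a modest difference does appear when the substituent changes elsewhere on the molecule: methoxy in place of fluoro gives a 2.3-fold higher number from compound 2 to compound 4 (0.36 log units; beyond the scatter), and methoxy in place of chloro gives a 2.6-fold higher number from compound 1 to compound 4 (0.41 log units; beyond the scatter). Nothing available explains these results.

Still open, on these data alone, is whether the same aryl exchange would matter as little in a compound carrying fluoro or chloro instead of methoxy. Also open, as far as these compounds go, is whether an amine or a carboxylic acid in place of the aryl group at this position would move the number beyond the scatter.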